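The compounds below may be only part of what the source reports. "The series", "measured", "known", "first", "only" and "open" are said of these compounds alone.

Measured compounds:
compound 1 `CCSc1nn2cc(-c3cc4ccccc4o3)nc2s1` gives 2900 nM
compound 2 `COc1cc(OCc2ccccc2OCc2ccccc2)c2cc(-c3cn4nc(OC)sc4n3)oc2c1` gives 3.2 nM
compound 3 `COc1cc(OCc2cccc(Oc3ccccc3)c2)c2cc(-c3cn4nc(OC)sc4n3)oc2c1` gives 1.2 nM

In a functional assay on HEK293 cells for antagonist activity at proteinase-activated receptor 4 (Homo sapiens), read by FLIPR and calcium flux, with a stated time of 30 min (on this read-out lower numbers stand for stronger inhibition and higher numbers for weaker inhibition), compound 1 stands highest of the three numbers. Compound 2 and compound 3 both give lower numbers than compound 1, and both gaps lie well beyond the scatter. Both of those compounds differ from compound 1 in several places at once and offer no guide to any single exchange.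

Compound 4 `c1ccc2oc(-c3cn4nc(C5CC5)sc4n3)cc2c1` is not yet measured. It differs from compound 1 by cyclopropyl in place of ethylsulfanyl on an aromatic carbon. Going by the values given here, no measured pair in this set shows that exchange, so there is nothing to anchor its size. The step from compound 1 to compound 4 in this assay is expected to be small, in no sure direction, and likely within the scatter, as a 1.2-fold lower number from compound 1 to compound 4 (0.06 log units; within the scatter). Compound 4 is expected to give 2500 nM, with a range from 800 nM to 8000 nM.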

Compound 4, half-maximal inhibitory concentration: 530 nM
Compound 4: the middle estimate sits 4.7-fold (0.67 log units) above what was measured; measured number below the stated range.
By their numbers in this assay, from the lowest: compound 3; then compound 2; then compound 4; then compound 1.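

In this assay, going by these compounds alone, cyclopropyl in place of ethylsulfanyl on this aromatic carbon gives a 5.5-fold lower number from compound 1 to compound 4 (0.74 log units; beyond the scatter), the first single-place step. This position therefore responds to the group it carries, even though both groups have 3 heavy atoms. Nothing at hand accounts for the step.

Going by these compounds, whether an amine or a longer carbon chain at this position would move the number further remains open. Also open, on these data alone, is whether cyclopropyl would give a similar step on the core of compound 3.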